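The compounds below may be only part of what the source reports. "The series", "measured", "known", "first", "only" and "open" are said of these compounds alone.

Measured so far in an ADME assay on Huh-7 cells (Homo sapiens) for cytotoxicity; a lower number here means that less compound is tolerated, a higher number that more compound is tolerated:
compound 1 `NC(=S)N1CCc2c(OCCCCCOc3ccc(Cl)cc3)cccc21` — > 50000 nM, a limit and not a number
compound 2 `Cc1ccc(C(=O)NC(=S)N2CCc3c(OCCCCCOc4ccc(Cl)cc4)cccc32)cc1` — > 50000 nM, a limit and not a number

Compound 2 stands at a limit only: in this assay compound 2 gives > 50000 nM, which is a limit of the assay rather than a number. For compound 1 the value is likewise a limit, so the step that the two limits leave unreadable from compound 1 to compound 2 cannot be read in either direction. By the limit of > 50000 nM in this assay, at which 2 of the 2 values shown sit, every value shown sits at that limit. Compound 3 `CCCC(=O)NC(=S)N1CCc2c(OCCCCCOc3ccc(Cl)cc3)cccc21` differs from compound 2 in propyl in place of 4-methylphenyl on a carbonyl carbon. Among the measured compounds shown here, no measured step bears on this change; the only step available, a step that the two limits leave unreadable from compound 1 to compound 2, is unreadable. With nothing to suggest movement, the expectation for compound 3 is that it stays at the limit too, so the expected step that the limit leaves unreadable from compound 2 to compound 3 is none beyond the scatter. Compound 3 is therefore estimated at 80000 nM, with a range from 35000 nM to 200000 nM, and will most likely again be reported only as a limit.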

Compound 3, half-maximal cytotoxic concentration: > 50000 nM
Compound 3 was reported as a limit; the forecaster's own chance of this, stated with the estimate: 85%; the middle value lies beyond the limit too.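

In this assay compound 3 gives > 50000 nM, a limit and not a number. No step among compound 1, compound 2 and compound 3 can be read: the limit of > 50000 nM in this assay, at which 3 of the 3 values shown sit.

The compounds shown leave open whether any change on the amide-type nitrogen gives a measurable cytotoxic concentration.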